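Tetrahydropyranyl-core series: tail flick read-out, isobutyl step

The source may hold more compounds than are shown below. What is called first, only, known or untested is meant among the compounds shown, and "the series" means these compounds.

Measured compounds:
- compound 1, `CSCC[C@H](NC(=O)CN(c1nc(Cl)nc2[nH]cnc12)C1CC1)C(=O)OCc1ccccc1`: 44.6%
- compound 2, `C[C@H](NC(=O)CN(c1nc(Cl)nc2[nH]cnc12)C1CC1)C(=O)O`: 43.5%
- compound 3, `CC(C)[C@H](NC(=O)CN(c1ncnc2c1ncn2C1CCCCO1)C1CC1)C(=O)OCc1ccccc1`: 30.1%

In a functional assay on the whole organism (Tail, strain ICR) with Mus musculus as the target, in the tail flick test, with a stated time of 90 min, at a dose of 25 umol/kg by the oral route (on this read-out lower numbers stand for a weaker effect and higher numbers for a stronger effect at the one dose given), compound 1 gives 44.6% and compound 2 gives 43.5%. Compound 3 gives 30.1% in this assay, the lowest of the three numbers; its gap to compound 2 and its gap to compound 1 both lie beyond the scatter, so compound 3 stands apart from the other two. Compound 1 and compound 2 lie within the scatter of each other, and no order between them is claimed.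

Compound 4, `CC(C)C[C@H](NC(=O)CN(c1ncnc2c1ncn2C1CCCCO1)C1CC1)C(=O)OCc1ccccc1`, differs from compound 3 in one place: isobutyl in place of isopropyl on a saturated chain carbon bound to an amide-type nitrogen and a carbonyl carbon. For the measured compounds named here, no pair of measured compounds differs in one place, so the size of such a step has no direct precedent here. The change is small in count, and the step from compound 3 to compound 4 in this assay is expected to be small, if anything a slight rise, and may well stay within the scatter: a number 4.9 percentage points higher from compound 3 to compound 4 (within the scatter). Compound 4 is estimated to give 35% in this assay, with a range from 15% to 55%.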

Compound 4, a percentage reported as activity, at one dose (the size of the read-out at that dose, not a potency): 28.2%
Estimate against measurement, compound 4: 6.8 percentage points above, and the stated range covers the measured number.
By their numbers in this assay, from the lowest: compounds 4 and 3 (each within the scatter of the next); then compounds 2 and 1 (each within the scatter of the next).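

In this assay, for the compounds shown here, isobutyl in place of isopropyl on a saturated chain carbon bound to an amide-type nitrogen and a carbonyl carbon gives a number 1.9 percentage points lower from compound 3 to compound 4 (within the scatter), and this is the first step that can be read across a single place. At this position, and at the one dose and time given, the read-out does not separate the two branched chains, so this change alone gives no handle on the effect. Nothing at hand explains this outcome or bears on it.

Going by these compounds, whether the same carbon responds to a group of another kind remains open: a benzyl, a hydroxymethyl, a carboxylic acid or an amine at the end of a longer chain could each give a larger step than this one. Also open, on these data alone, is whether compound 3 and compound 4 would separate at other doses or times, and the free carboxylic acid in place of the benzyl ester has no partner on this core that differs from either compound in one place.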